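From piperidin-4-yl to 3-fluorophenyl on a shared core

A few compounds are considered here, and "the series" means these few. Any claim that something is new, unique, unknown or untested is made for them only; others in the source may bear on it.

Of the compounds shown here, three sharing one core have been measured in an ADME assay on HepG2 cells (Homo sapiens) for cytotoxicity, read by MTT assay, with a stated time of 24 h; a lower number here means that less compound is tolerated, a higher number that more compound is tolerated. Compound 1 `CC(C)=CCC1=C(OCc2cn(-c3ccnc4cc(Cl)ccc34)nn2)C(=O)c2ccccc2C1=O` gives 1940000 nM. Compound 2 `CC(C)=CCC1=C(OCc2cn(C3CCNCC3)nn2)C(=O)c2ccccc2C1=O` gives 570000 nM, and compound 3 `CC(C)=CCC1=C(OCc2cn(Cc3ccccc3)nn2)C(=O)c2ccccc2C1=O` gives 414000 nM. Compound 2 therefore stands close to compound 3, as a 1.4-fold lower number from compound 2 to compound 3 (0.14 log units; within the scatter) lies within the scatter, while a 3.4-fold lower number from compound 1 to compound 2 (0.53 log units; beyond the scatter) sets it clearly apart from compound 1.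

Compound 4 `CC(C)=CCC1=C(OCc2cn(-c3cccc(F)c3)nn2)C(=O)c2ccccc2C1=O` has not yet been measured. It carries 3-fluorophenyl in place of piperidin-4-yl on an aromatic nitrogen. All three measured steps involve changes at this same place. Exchanging piperidin-4-yl for benzyl made no difference beyond the scatter, whereas a 4.7-fold lower number from compound 1 to compound 3 (0.67 log units; beyond the scatter) is a modest step. For the measured compounds named here, as compound 4 will have, an aromatic ring is bonded directly to that nitrogen in compound 1, the only measured compound with such a ring there, and it stands highest at 1940000 nM. This is a single case with a much larger group, so it supports only a slight upward lean. The estimated step is a 1.1-fold higher number from compound 2 to compound 4 (0.06 log units; within the scatter), which means that no change beyond the scatter is expected in this assay. The expected value for compound 4 is 650000 nM, with an estimated range of 280000 nM to 1600000 nM.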

Compound 4, half-maximal cytotoxic concentration: 265000 nM
The estimate for compound 4 lay 2.5-fold (0.39 log units) above the measured number, and the stated range ends above it.
By their numbers in this assay, from the lowest: compounds 4, 3 and 2 (each within the scatter of the next, the first and the last beyond it); then compound 1.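

In this assay, an aromatic ring bonded directly to the aromatic nitrogen does not by itself give a high number: 3-fluorophenyl shares that direct attachment with the 7-chloroquinolin-4-yl group of compound 1, yet the data show a 7.3-fold lower number from compound 1 to compound 4 (0.86 log units; beyond the scatter). The earlier lean towards a higher number therefore does not hold, and the exchange of piperidin-4-yl for 3-fluorophenyl moves the number the other way, with a 2.2-fold lower number from compound 2 to compound 4 (0.33 log units; beyond the scatter), a step that benzyl in compound 3 did not produce beyond the scatter. Compound 4 cannot be separated from compound 3, given a 1.6-fold lower number from compound 3 to compound 4 (0.19 log units; within the scatter), so at this position the high number remains confined to compound 1, and no information is available to explain any of these differences.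

The compounds shown leave open how much the fluorine contributes, for which plain phenyl would be the direct comparison, and whether the high number of compound 1 depends on its chlorine or on the fused ring system itself, which quinolin-4-yl without chlorine would address. They also leave open how an amine or a carboxylic acid on the phenyl ring would behave at this position.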